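The source may hold more compounds than are shown below. What is called first, only, known or untested is meant among the compounds shown, and "the series" means these compounds.

Of the compounds shown here, three sharing one core have been measured so far in a functional assay on PANC-1 cells (Homo sapiens) for inhibition, read by MTT assay, with a stated time of 24 h; a lower number here means a stronger inhibitor, a higher number a weaker inhibitor. Compound 1 `CC1(C)[C@H]2CC[C@]1(C)N(Cc1cn(-c3ccccc3Br)nn1)C(=O)C2` gives 280 nM there, compound 2 `CC1(C)[C@H]2CC[C@]1(C)N(Cc1cn(-c3cccc(C#N)c3)nn1)C(=O)C2` gives 260 nM there, and compound 3 `CC1(C)[C@H]2CC[C@]1(C)N(Cc1cn(-c3ccccc3F)nn1)C(=O)C2` gives 150 nM there. Compound 3 does not stand apart from the other two: the steps among the three, a 1.1-fold lower number from compound 1 to compound 2 (0.03 log units; within the scatter), a 1.9-fold lower number from compound 1 to compound 3 (0.27 log units; within the scatter) and a 1.7-fold lower number from compound 2 to compound 3 (0.24 log units; within the scatter), all lie within the scatter, so these numbers cannot be ranked.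

Compound 4 `CC1(C)[C@H]2CC[C@]1(C)N(Cc1cn(-c3cccc(Cl)c3)nn1)C(=O)C2` has not been measured yet. It differs from compound 3 in one place, with 3-chlorophenyl in place of 2-fluorophenyl on an aromatic nitrogen. Among the measured compounds shown here, no measured compound carries chlorine, so this exact swap has no direct precedent. The closest guide is compound 2, which also differs from compound 3 only in this group, and its step of a 1.7-fold lower number from compound 2 to compound 3 (0.24 log units; within the scatter) stayed within the scatter. The swap of bromo for fluoro, a 1.9-fold lower number from compound 1 to compound 3 (0.27 log units; within the scatter), stayed within it as well.

No step beyond the scatter is therefore expected in this assay, and the estimated step is a 1.5-fold higher number from compound 3 to compound 4 (0.17 log units; within the scatter) in size and direction. For compound 4 the expected value is 220 nM, with an estimated range from 110 nM to 440 nM.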

Compound 4, half-maximal inhibitory concentration: 260 nM
Compound 4: middle estimate off by 1.2-fold (0.07 log units), on the low side; the range from low to high includes it.
By their numbers in this assay, from the lowest: compounds 3, 2, 4 and 1 (each within the scatter of the next).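

A third halogen on the phenyl group carried by the aromatic nitrogen does not shift the picture in this assay: 3-chlorophenyl in place of 2-fluorophenyl gives a step of (a 1.7-fold higher number from compound 3 to compound 4 (0.24 log units; within the scatter)), and 3-chlorophenyl in place of 2-bromophenyl gives a step of (a 1.1-fold lower number from compound 1 to compound 4 (0.03 log units; within the scatter)). Chloro in place of cyano on an aromatic carbon gives (no change at the digits printed from compound 2 to compound 4 (within the scatter)), so all four phenyl groups now lie within the scatter of one another and cannot be ranked at this position. No measurement is available that bears on why these groups give such similar numbers.

Still open, going by these compounds, is whether a group of another kind on this phenyl ring, such as an amine, a carboxylic acid or a methoxy group, would produce a step beyond the scatter. Also open, on these data alone, is what moving a single halogen around the ring would do, since the halogen and its place change together among 2-bromophenyl, 2-fluorophenyl and 3-chlorophenyl, and these compounds cannot separate the two changes.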